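This account rests on a few compounds, and the source may have more. Where it says the series, first, only, none or still open, it means among the compounds named here.

Measured compounds:
compound 1 `Cn1nnnc1SCC(=O)N/N=C/c1ccc(F)cc1` — 10000000 nM
compound 2 `Cn1nnnc1SCC(=O)N/N=C/c1ccc(Cl)cc1` — 2100000 nM
compound 3 `Cn1nnnc1SCC(=O)N/N=C/c1ccccc1F` — 2000000 nM

In an ADME assay on NIH3T3 cells (Mus musculus) for cytotoxicity, read by XTT assay, with a stated time of 24 h (a higher number here means a weaker inhibitor, a lower number a stronger inhibitor), compound 3 gives 2000000 nM, the lowest number of the three shown. Compound 2 gives 2100000 nM in this assay, a number that lies within the usual scatter of that of compound 3, so the two cannot be told apart. Compound 1 gives 10000000 nM in this assay, and its gap to compound 3 is beyond the scatter.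

Compound 4 `Cn1nnnc1SCC(=O)N/N=C/c1ccccc1O` differs from compound 3 in one place: hydroxy in place of fluoro on an aromatic carbon. The only measured step among these compounds, a 4.8-fold lower number from compound 1 to compound 2 (0.68 log units; beyond the scatter), exchanges one halogen for another at a different place on the ring and says nothing about a hydroxy entering. For the measured compounds named here, no measured step therefore bears on the change from compound 3 to compound 4, and no movement beyond the scatter can be argued for in this assay. Compound 4 is expected to stay close to compound 3, the step being estimated as no change at the digits printed from compound 3 to compound 4 (within the scatter). The estimate for compound 4 in this assay is 2000000 nM, with a range from 600000 nM to 7000000 nM.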

Compound 4, half-maximal inhibitory concentration: > 10000000 nM
Compound 4: only a limit was reported (the forecaster's own chance of this, stated with the estimate: 25%); at least 5.0-fold (0.69 log units) between middle value and limit.
By their numbers in this assay, from the lowest: compounds 3 and 2 (each within the scatter of the next); then compound 1.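

Compound 4 has only a limit in this assay, > 10000000 nM. Swapping the fluoro for a hydroxy, at a place ortho to a large group, still gives an at least 5.0-fold higher number from compound 3 to compound 4 (0.69 log units; beyond the scatter), which shows that the number at this place depends on the group it carries; the earlier compounds showed only one halogen exchanged for another, in the step from compound 1 to compound 2. The size of this step is a lower bound and its true size stays unknown: the limit of > 10000000 nM in this assay, at which 1 of the 4 values shown sits.

As far as these compounds go, what remains open is whether the change comes from the oxygen itself or from the hydrogen on it, which a methoxy group at this place could help to separate. From the compounds shown here alone, it is also open whether an amine here would follow hydroxy or fluoro, and whether hydroxy at the ring place holding the fluoro of compound 1 would behave the same way.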